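Amino for hydrogen on the core of compound 1

This account rests on a few compounds, and the source may have more. Where it says the series, first, only, none or still open, it means among the compounds named here.

Measured in a functional assay on HepG2 cells (Homo sapiens) for antiproliferative activity, read by XTT assay, with a stated time of 72 h; a lower number here means a stronger inhibitor, a higher number a weaker inhibitor:
compound 1 `O=c1[nH]cnc2c1c(-c1cc3ccccc3o1)cn2[C@@H]1O[C@H](CO)[C@@H](O)[C@H]1O`: > 20000 nM
compound 2 `O=c1[nH]cnc2c1c(-c1cccs1)cn2[C@@H]1O[C@H](CO)[C@@H](O)[C@H]1O`: > 20000 nM
compound 3 `O=c1[nH]cnc2c1c(-c1ccoc1)cn2[C@@H]1O[C@H](CO)[C@@H](O)[C@H]1O`: 12100 nM

Compound 1 stands at a limit of this assay, not at a number. Compound 2 likewise reports only a limit. Compound 3 alone gives a number. The measured steps all concern the aryl group on the shared core: a step that the two limits leave unreadable from compound 1 to compound 2; an at least 1.6-fold lower number from compound 1 to compound 3 (0.21 log units; that floor lies within the scatter); an at least 1.6-fold lower number from compound 2 to compound 3 (0.21 log units; that floor lies within the scatter). Two of these rest on (the limit of > 20000 nM in this assay, at which 2 of the 3 values shown sit), so their size is only a floor.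

Compound 4 `Nc1nc2c(c(-c3cc4ccccc4o3)cn2[C@@H]2O[C@H](CO)[C@@H](O)[C@H]2O)c(=O)[nH]1` is the next compound, to be measured in this assay. It differs from compound 1 by amino in place of hydrogen on an aromatic carbon. For the measured compounds named here, none of the measured steps touches this place on the core; all three change the aryl group and keep the hydrogen. Going by the values given here, there is thus no measured step that bears directly on the change, and with compound 1 itself sitting at a limit the expectation can only be weak. The step is expected to be a number no higher from compound 1 to compound 4 (the limit leaves the size open), that is nothing beyond the scatter in either direction. For compound 4 the value is estimated at 20000 nM, within 7000 nM to 60000 nM, with a good chance that this assay again reports only a limit.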

Compound 4, half-maximal inhibitory concentration: > 20000 nM
Compound 4 was reported as a limit; the forecaster's own chance of this, stated with the estimate: 65%; the middle value sits exactly at the limit.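

In this assay no step can be read from compound 1 to compound 4, because both compounds stand at a limit and not at a number: the limit of > 20000 nM in this assay, at which 3 of the 4 values shown sit.

The compounds shown leave open whether amino in place of hydrogen on the shared core changes antiproliferative activity in either direction.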